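Removing the Methoxy from Compound 2

The source may hold more compounds than are shown below. What is called first, only, known or untested is meant among the compounds shown, and "the series" means these compounds.

Compound 1 `COc1ccc(-c2cnc(NC(=O)CCCCCCNC(=O)C(O)(O)C(F)(F)F)s2)cc1`: 1960 nM
Compound 2 `COc1ccc2sc(NC(=O)CCCCCCNC(=O)C(O)(O)C(F)(F)F)nc2c1`: 2280 nM

In a functional assay on HT-1080 cells (Homo sapiens) for inhibition, read by colorimetric assay, with a stated time of 3 days (on this read-out higher numbers stand for weaker inhibition and lower numbers for stronger inhibition), compound 2 gives 2280 nM, which lies within the usual scatter of compound 1 at 1960 nM, so the two cannot be told apart. Compound 3 `O=C(CCCCCCNC(=O)C(O)(O)C(F)(F)F)Nc1nc2ccccc2s1` is compound 2 with hydrogen in place of methoxy on an aromatic carbon. Among the compounds with values here, both measured compounds carry the methoxy, so no measurement yet shows directly what losing it does. Compound 1 at 1960 nM and compound 2 at 2280 nM differ in their cores yet stay within the scatter, and this modest evidence points to a small effect here too. No step beyond the scatter is expected in this assay, in either direction. The expected step of a 1.1-fold higher number from compound 2 to compound 3 (0.04 log units; within the scatter) is therefore small. For compound 3 the estimate is 2500 nM, with an expected range of 1000 nM to 6000 nM.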

Compound 3, half-maximal inhibitory concentration: 2650 nM
Beside the measured number, compound 3's estimate is 1.1-fold (0.03 log units) below it; the measured number falls inside the stated range.
By their numbers in this assay, from the lowest: compounds 1, 2 and 3 (each within the scatter of the next).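

Within the data shown here, compound 2 and compound 3 are the first pair here that differ in one place only, so the methoxy can now be judged directly rather than inferred from compounds with different cores. In this assay, the swap to hydrogen on this six-membered aromatic ring reads as a 1.2-fold higher number from compound 2 to compound 3 (0.07 log units; within the scatter), a step within the scatter. At this position, then, the methoxy, with its 2 heavy atoms and 1 hydrogen-bond acceptor, can be replaced by hydrogen with no difference this read-out can detect, and no other measurement is at hand to explain the result.

From the compounds shown here alone, it remains open whether another group at this position, such as an amine or a carboxylic acid, would move the number beyond the scatter. Also open, going by these compounds, is whether the same swap on the core of compound 1 would read the same way.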